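The compounds below may be only part of what the source reports. "The series", "measured", "known", "first", "only" and "open" are said of these compounds alone.

Measured compounds:
- compound 1 `O=C1/C(=C\c2c(Cl)cccc2Cl)c2ccccc2N1c1c(Cl)cccc1Cl`: > 100 ug/mL
- compound 2 `COc1ccc(/C=C2\C(=O)N(c3c(Cl)cccc3Cl)c3ccccc32)cc1`: > 100 ug/mL
- compound 3 `O=C1/C(=C\c2cccc(Cl)c2)c2ccccc2N1c1c(Cl)cccc1Cl`: "not determined" (no result reported)

All three share one core and differ in the ring attached on a double-bonded chain carbon. In a functional assay on MCF7 cells (Homo sapiens) for cytotoxicity, read by MTT assay, with a stated time of 72 h (on this read-out higher numbers stand for an effect only at larger amounts of compound and lower numbers for an effect already at smaller amounts), compound 1 gives only a limit, > 100 ug/mL. In this assay compound 2 likewise gives only a limit, > 100 ug/mL. For compound 3 this assay shows no result at all, "not determined" (no result reported). For the measured compounds named here, the one step that can be traced, a step that the two limits leave unreadable from compound 1 to compound 2, has no readable size, since both of its ends are limits. So compound 3 stands without a number of its own, and the two other values shown for this series are limits rather than measurements; the only evidence on hand is the limit of > 100 ug/mL in this assay, at which 2 of the 3 values shown sit.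

Compound 4 `O=C1/C(=C\c2ccc(Cl)cc2)c2ccccc2N1c1c(Cl)cccc1Cl` is not yet measured. It differs from compound 3 by 4-chlorophenyl in place of 3-chlorophenyl on a double-bonded chain carbon bound to a double-bonded ring carbon. Going by the values given here, no measured step bears directly on this change, and the step between compound 1 and compound 2 gives no size to lean on. With nothing beyond a limit seen anywhere in this series, the expectation for compound 4 in this assay is that it will again show an effect only at the upper end of the tested range, estimated at 100 ug/mL, within a range of 30 ug/mL to 300 ug/mL.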

Compound 4, concentration for half-maximal effect: 5 ug/mL
For compound 4 the middle estimate is 20-fold (1.30 log units) above the measured one, and the stated range ends above it.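

Compound 4 shows that the ring on a double-bonded chain carbon bound to a double-bonded ring carbon can carry a readable effect in this assay, where the earlier compounds had offered only this: the limit of > 100 ug/mL in this assay, at which 2 of the 4 values shown sit.

Two comparisons give the size of the change: there is an at least 20-fold lower number from compound 2 to compound 4 (1.30 log units; beyond the scatter), with chloro in place of methoxy on an aromatic carbon, and there is an at least 20-fold lower number from compound 1 to compound 4 (1.30 log units; beyond the scatter), with 4-chlorophenyl in place of 2,6-dichlorophenyl. Both steps start from a limit, so each gives a smallest possible size and not an exact one.

Going by these compounds, compound 3 carries no result, so the change from 3-chlorophenyl to 4-chlorophenyl, the closest comparison for compound 4, has no readable size, and the part played by where the chlorine sits stays open. Also open, on these data alone, is how an amine, a carboxylic acid or a longer chain such as propyl would fare in place of the chloro of compound 4.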